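The source may report more compounds than this note shows. Statements on the series, on what has been measured and on what is new or still open speak of the compounds shown alone.

Working notes on the series. In a physicochemical assay for solubility, in phosphate buffer, with a stated time of 18 h (on this read-out lower numbers stand for lower solubility and higher numbers for higher solubility), compound 1 `Cc1nc(C(C)(C)C)nc2nc(N)c(C#N)c(N)c12` gives 37000 nM. In this assay, compound 2 `CC(C)(C)c1nc(-c2ccc(C(=O)O)s2)c2c(N)c(C#N)c(N)nc2n1` gives > 1000000 nM, which is a limit of the assay and not a number. Compound 2 therefore has no exact position, and the limit of > 1000000 nM in this assay, at which 1 of the 2 values shown sits, is all that can be said of it.

Compound 3 `CC(C)(C)c1nc(-c2ncn[nH]2)c2c(N)c(C#N)c(N)nc2n1` has not been measured. The change from compound 2 is 1H-1,2,4-triazol-5-yl in place of 5-carboxythiophen-2-yl on an aromatic carbon.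

For the measured compounds named here, only one measured step bears on this, and it is large: an at least 27-fold higher number from compound 1 to compound 2 (1.43 log units; beyond the scatter). It brought in the group that now leaves. Going by the values given here, no measured step brings in 1H-1,2,4-triazol-5-yl, so the size of the new step remains uncertain. In this assay, a lower number is expected, probably by a margin beyond the scatter, with compound 3 inside the span opened by the step from compound 1 at 37000 nM.

The expected step is an at least 6.6-fold lower number from compound 2 to compound 3 (0.82 log units; beyond the scatter). For compound 3 the estimate is 150000 nM, with an expected range of 30000 nM to 700000 nM.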

Compound 3, solubility: 64500 nM
Beside the measured number, compound 3's estimate is 2.3-fold (0.37 log units) above it; low and high end bracket the measured number.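

At this position, on an aromatic carbon next to the ring nitrogen, the change from 5-carboxythiophen-2-yl to 1H-1,2,4-triazol-5-yl in this assay gives an at least 15-fold lower number from compound 2 to compound 3 (1.19 log units; beyond the scatter). Set against the methyl group of the core of compound 1, the same group gives a 1.7-fold higher number from compound 1 to compound 3 (0.24 log units; within the scatter), so 1H-1,2,4-triazol-5-yl and methyl cannot be told apart in this assay, and the series now shows that not every five-membered aromatic ring at this position gives a number like that of compound 2. Compound 2 stands at a limit of the assay and not at a number, so its step to the triazole marks a bound and not an exact size: the limit of > 1000000 nM in this assay, at which 1 of the 3 values shown sits.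

The compounds shown leave open whether the carboxylic acid or the thiophene ring that carries it sets compound 2 apart, which a plain thiophen-2-yl or a phenyl bearing the same carboxylic acid would separate. Also open, on these data alone, is whether an aminomethyl group at this position would sit with methyl and 1H-1,2,4-triazol-5-yl or with 5-carboxythiophen-2-yl, and whether any of this holds once the tert-butyl group is replaced.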